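Lengthening the Carbamate Amine Chains: Compound 2 to Compound 3

The source may hold more compounds than are shown below. What is called first, only, known or untested is meant among the compounds shown, and "the series" means these compounds.

Compound 1 `CCCC(C)NC(=O)OCC1CN(C(=O)c2cc(OC)c(OC)c(OC)c2)CCN1C(=O)c1cc(OC)c(OC)c(OC)c1`: 100 nM
Compound 2 `CCCN(CCC)C(=O)OCC1CN(C(=O)c2cc(OC)c(OC)c(OC)c2)CCN1C(=O)c1cc(OC)c(OC)c(OC)c1`: 380 nM

For the measured compounds named here, in a functional assay (Oryctolagus cuniculus) for inhibition of platelet-activating factor receptor (Cavia porcellus) (on this read-out lower numbers stand for stronger inhibition and higher numbers for weaker inhibition), compound 2 gives the higher of the two numbers, the only step measured being a 3.8-fold higher number from compound 1 to compound 2 (0.58 log units; beyond the scatter). Compound 3 `CCCCCN(CCCCC)C(=O)OCC1CN(C(=O)c2cc(OC)c(OC)c(OC)c2)CCN1C(=O)c1cc(OC)c(OC)c(OC)c1` differs from compound 2 by dipentylamino in place of dipropylamino on a carbonyl carbon. Going by the values given here, no measured step touches chain length in this group; the one known step concerns a different amine and is modest. Among the compounds with values here, with no direct precedent, a change of only modest size is expected, direction uncertain, so compound 3 is estimated at 450 nM (range 150 nM to 1400 nM). This corresponds to an expected step of a 1.2-fold higher number from compound 2 to compound 3 (0.07 log units; within the scatter).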

Compound 3, half-maximal inhibitory concentration: 11400 nM
The estimate for compound 3 lay 25-fold (1.40 log units) below the measured number; the whole stated range lies below it.
By their numbers in this assay, from the lowest: compound 1; then compound 2; then compound 3.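

In this assay, this position on a carbonyl carbon proves far more sensitive than the first pair suggested: dipentylamino in place of dipropylamino gives a 30-fold higher number from compound 2 to compound 3 (1.48 log units; beyond the scatter) and is a large step rather than a modest one. Set against (1-methylbutyl)amino, dipentylamino gives a 110-fold higher number from compound 1 to compound 3 (2.06 log units; beyond the scatter) and so marks compound 3 as the weakest inhibitor of the three. Nothing available explains this loss.

On these data alone, whether the loss builds gradually through dibutylamino or appears only with dipentylamino remains open. So does whether a single straight chain, such as pentylamino, would behave like (1-methylbutyl)amino.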